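A few compounds are considered here, and "the series" means these few. Any claim that something is new, unique, unknown or untested is made for them only; others in the source may bear on it.

The measured compounds:

compound 1 `Nc1ncnc2c1ncn2CC(O)C(=O)OCCO` — in a functional assay on HeLa cells (Homo sapiens) for cytotoxicity (a lower number here means that less compound is tolerated, a higher number that more compound is tolerated), compound 1 gives > 400 ug/mL, a limit of the assay.

compound 2 `COCCOC(=O)C(O)Cn1cnc2c(N)ncnc21` — in this assay compound 2 gives > 400 ug/mL, also a limit of the assay.

Both values sit at the limit of > 400 ug/mL in this assay, at which 2 of the 2 values shown sit, so the step that the two limits leave unreadable from compound 1 to compound 2 cannot be read: compound 2 stands where compound 1 stands, at a limit rather than a number, and nothing in these two measurements separates the two.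

Compound 3 `COC(=O)C(O)Cn1cnc2c(N)ncnc21` differs from compound 2 by hydrogen in place of methoxymethyl on a saturated chain carbon bound to an oxygen next to a carbonyl group. Among the compounds with values here, the only measured step, a step that the two limits leave unreadable from compound 1 to compound 2, bears on a nearby part of the chain but is unreadable, so no size or direction can be taken from it. The step of a number no higher from compound 2 to compound 3 (the limit leaves the size open) is therefore expected to stay within the scatter. In this assay compound 3 is expected to give about 400 ug/mL, most likely reported again as a limit, with a range from 200 ug/mL to 800 ug/mL.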

Compound 3, minimum cytotoxic concentration: > 400 ug/mL
Compound 3 ended at the assay's limit (the forecaster's own chance of this, stated with the estimate: 85%); the middle value sits exactly at the limit.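

In this assay, within the data shown here, compound 3 gives > 400 ug/mL, a limit of the assay, so no step among compound 1, compound 2 and compound 3 can be read: the limit of > 400 ug/mL in this assay, at which 3 of the 3 values shown sit. The compounds shown leave open at what concentration any of the three turns cytotoxic, and whether the differences among them alter that concentration.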